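The source may report more compounds than this note shows. Statements on the series, on what has been measured and on what is new or still open speak of the compounds shown alone.

Measured so far in a functional assay on MCF7 cells (Homo sapiens) for inhibition, read by fluorescence, with a stated time of 72 h; on this read-out lower numbers stand for stronger inhibition of growth and higher numbers for weaker inhibition of growth:

- Compound 1 `COc1ccc(Nc2nc(N[C@H]3CC[C@H](N)CC3)nc3c2ncn3CCC(C)C)c(OC)c1` gives 6300 nM
- Compound 2 `CC(C)CCn1cnc2c(Nc3ccc(Cl)cc3)nc(N[C@H]3CC[C@H](N)CC3)nc21` gives 2700 nM
- Compound 3 `CCCCn1cnc2c(NCc3cccc(Cl)c3)nc(N[C@H]3CC[C@H](N)CC3)nc21` gives 2200 nM

Compound 3 sits within the scatter of compound 2, and the numbers of both lie beyond the scatter under that of compound 1. Compound 4 `CC(C)CCn1cnc2c(NCc3cccc(Cl)c3)nc(N[C@H]3CC[C@H](N)CC3)nc21` has not yet been measured. It differs from compound 3 by methyl in place of hydrogen on a saturated chain carbon bound to two saturated chain carbons, which turns butyl into isopentyl. For the measured compounds named here, no measured step covers this change. The only one, a 2.3-fold lower number from compound 1 to compound 2 (0.37 log units; beyond the scatter), is modest and concerns the group on a nitrogen on an aromatic ring, so it bears on this change only indirectly. Compound 2 carries the isopentyl chain and compound 3 the butyl chain, and their values lie within the scatter of each other, although they also differ elsewhere. Going by the values given here, with compound 3 at 2200 nM and no measured step on this chain, no step beyond the scatter is expected in this assay. The estimated step is a 1.1-fold lower number from compound 3 to compound 4 (0.04 log units; within the scatter) and it is expected to stay within the scatter. The estimate for compound 4 is 2000 nM, with an expected range from 900 nM to 4500 nM.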

Compound 4, concentration for 50% growth inhibition: 4700 nM
Compound 4: the middle estimate sits 2.4-fold (0.37 log units) below what was measured, and the stated range ends below it.
By their numbers in this assay, from the lowest: compounds 3, 2, 4 and 1 (each within the scatter of the next, the first and the last beyond it).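

In this assay, for the compounds shown here, the methyl on a saturated chain carbon bound to two saturated chain carbons, which turns butyl into isopentyl, gives the first direct reading on this chain, and with 3-chlorobenzyl on the nitrogen it counts against growth inhibition, modestly but beyond the scatter (a 2.1-fold higher number from compound 3 to compound 4 (0.33 log units; beyond the scatter)). With isopentyl held, 3-chlorobenzyl stays within the scatter of both 4-chlorophenyl (a 1.7-fold higher number from compound 2 to compound 4 (0.24 log units; within the scatter)) and 2,4-dimethoxyphenyl (a 1.3-fold lower number from compound 1 to compound 4 (0.13 log units; within the scatter)), so this change of group does not separate these pairs. Nothing at hand accounts for the step from butyl to isopentyl.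

The compounds shown leave open whether the same methyl counts equally with 4-chlorophenyl on the nitrogen. They also leave open how a longer chain, or a chain carrying an amine, would read at this position.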